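Trimethoxyphenyl hydrazone on the diaryl ether urea core

The compounds below may be only part of what the source reports. "The series", "measured", "known", "first", "only" and "open" are said of these compounds alone.

Compound 1 `CN(C)CCn1cnnc1-c1cc(Oc2ccc(NC(=O)N/N=C/c3cccc(Cl)c3Cl)cc2F)ccn1`: 72 nM
Compound 2 `CN(C)CCn1cnnc1-c1cc(Oc2ccc(NC(=O)N/N=C/c3cc(Br)c(O)c(Br)c3)cc2F)ccn1`: 3760 nM
Compound 3 `COc1ccc(/C=N/NC(=O)Nc2ccc(Oc3ccnc(-c4nncn4CCN(C)C)c3)c(F)c2)c(OC)c1`: 1570 nM

In a functional assay on NCI-H460 cells (Homo sapiens) for cytotoxicity, read by MTT assay, with a stated time of 72 h (on this read-out lower numbers stand for stronger inhibition and higher numbers for weaker inhibition), compound 1 gives the lowest number of the three measured compounds; its nearest neighbour is compound 3, and the furthest is compound 2. Two steps leave compound 1 and both change the aryl group on the carbon with a double bond to nitrogen. The step of a 52-fold higher number from compound 1 to compound 2 (1.72 log units; beyond the scatter) is large, and the step of a 22-fold higher number from compound 1 to compound 3 (1.34 log units; beyond the scatter) is also large, so both replacements of the 2,3-dichlorophenyl group have weakened the effect well beyond the scatter. Between the two, the step of a 2.4-fold lower number from compound 2 to compound 3 (0.38 log units; beyond the scatter) is modest.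

Compound 4 `COc1cc(/C=N/NC(=O)Nc2ccc(Oc3ccnc(-c4nncn4CCN(C)C)c3)c(F)c2)cc(OC)c1OC` is not yet measured. It differs from compound 1 as follows: 3,4,5-trimethoxyphenyl in place of 2,3-dichlorophenyl on a carbon with a double bond to nitrogen. Of the measured steps, the change to the 2,4-dimethoxyphenyl group in compound 3 bears most directly on this one, since compound 4 also carries methoxy groups on the entering ring. Compound 4 is therefore expected to sit far from compound 1, with a step of a 25-fold higher number from compound 1 to compound 4 (1.40 log units; beyond the scatter) in the direction of a weaker effect, similar in size to the step of a 22-fold higher number from compound 1 to compound 3 (1.34 log units; beyond the scatter). Compound 4 is estimated at 1800 nM, in the range 500 nM to 6000 nM.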

Compound 4, half-maximal inhibitory concentration: 2770 nM
Compound 4: middle estimate off by 1.5-fold (0.19 log units), on the low side; low and high end bracket the measured number.
By their numbers in this assay, from the lowest: compound 1; then compounds 3, 4 and 2 (each within the scatter of the next, the first and the last beyond it).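

In this assay, the step of a 38-fold higher number from compound 1 to compound 4 (1.59 log units; beyond the scatter) adds a third replacement that falls well short of the 2,3-dichlorophenyl group on the carbon with a double bond to nitrogen, so compound 1 now stands apart from all three other aryl groups shown. The 3,4,5-trimethoxyphenyl group cannot be told apart from either of the others: the step of a 1.8-fold higher number from compound 3 to compound 4 (0.25 log units; within the scatter) and the step of a 1.4-fold lower number from compound 2 to compound 4 (0.13 log units; within the scatter) both lie within the scatter, which places compound 4 in an overlap between two compounds whose own difference lies just beyond it. No measurement given here bears on why the 2,3-dichlorophenyl group stands apart from these replacements.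

As far as these compounds go, it remains open whether the low number of compound 1 depends on chlorine itself or on where the substituents sit, which a 2,3-dimethylphenyl, 2,3-difluorophenyl, 3,5-dichlorophenyl or plain phenyl group at this place could help to separate. From the compounds shown here alone, it is equally open how an aryl group bearing an amine or a carboxylic acid would behave at this place.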